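Amino in Place of Hydroxy: Expecting Compound 3

The compounds below may be only part of what the source reports. "The series", "measured", "known", "first", "only" and "open" are said of these compounds alone.

Compound 2 `Cc1cn([C@H]2C[C@H](SSCCO)[C@@H](CO)O2)c(=O)[nH]c1=O` gives 128000 nM in a functional assay on MOLT-4 cells (Homo sapiens) for cytotoxicity (a higher number here means a weaker inhibitor, a lower number a stronger inhibitor), the highest of the two numbers measured. Compound 1 `Cc1cn([C@H]2C[C@H](SSc3ccccc3[N+](=O)[O-])[C@@H](CO)O2)c(=O)[nH]c1=O` gives 31000 nM, and the step of a 4.1-fold higher number from compound 1 to compound 2 (0.62 log units; beyond the scatter) put a 2-hydroxyethyl in place of a 2-nitrophenyl on a sulfur. Compound 3 `Cc1cn([C@H]2C[C@H](SSCCN)[C@@H](CO)O2)c(=O)[nH]c1=O` differs from compound 2 by amino in place of hydroxy on a saturated chain carbon, two bonds along the chain from a sulfur. Within the data shown here, no measured step swaps an amino for a hydroxy, so nothing here sets the size of this change. In this assay the change is expected to give no change at the digits printed from compound 2 to compound 3 (within the scatter), within the scatter. Compound 3 is estimated at 128000 nM, with a range from 45000 nM to 360000 nM.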

Compound 3, half-maximal inhibitory concentration: 163000 nM
Compound 3: the middle estimate sits 1.3-fold (0.10 log units) below what was measured; the measured number falls inside the stated range.
By their numbers in this assay, from the lowest: compound 1; then compounds 2 and 3 (each within the scatter of the next).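

In this assay, amino in place of hydroxy at the end of this chain gives a 1.3-fold higher number from compound 2 to compound 3 (0.10 log units; within the scatter) and stays within the scatter, so this assay does not tell the 2-aminoethyl and 2-hydroxyethyl groups apart. With 2-aminoethyl in place of 2-nitrophenyl on the sulfur, the step is a 5.3-fold higher number from compound 1 to compound 3 (0.72 log units; beyond the scatter) and lies beyond the scatter, in the same direction as the step to the 2-hydroxyethyl group. No measurement offered here explains either step. Still open, from the compounds shown here alone, is whether a carboxylic acid at the chain end, or a longer chain, would shift the number.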